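The source may report more compounds than this note shows. Statements on the series, on what has been measured and on what is new or still open speak of the compounds shown alone.

Compound 3, with the structure `CCC(=O)NCCCc1ccc(OC)c(F)c1`, stands second highest of the three numbers obtained so far in an assay on isolated protein for agonist activity at melatonin receptor type 1C (Xenopus laevis), read by spectrophotometry; on this read-out lower numbers stand for an effect already at smaller amounts and higher numbers for an effect only at larger amounts of compound. In this assay compound 3 gives 871 nM. Compound 1, with the structure `CCC(=O)NCc1ccc(F)c(OC)c1`, is the nearest of the other two and gives 2880 nM in this assay, a gap beyond the usual scatter. Compound 2, with the structure `CCCC(=O)NCCCc1ccc(F)c(OC)c1`, is the furthest of the other two and gives 0.891 nM in this assay, a gap far beyond the scatter.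

Compound 4, with the structure `CCCC(=O)NCCCc1ccc(OC)c(F)c1`, has not yet been measured. It differs from compound 3 in one place: methyl in place of hydrogen on a saturated chain carbon, two bonds along the chain from a carbonyl carbon. Read one bond further out, the change is propanoyl to propylcarbonyl on the amide.

Within the data shown here, no measured pair differs in just this one place, so the size of the step has to be judged from compound 2, whose structure carries the same propylcarbonyl group on a differently substituted core, together with a short step from compound 3 to compound 4 estimated as a 4.4-fold lower number from compound 3 to compound 4 (0.64 log units; beyond the scatter) in this assay. For compound 4 the expected value in this assay is 200 nM, within an estimated range from 40 nM to 900 nM.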

Compound 4, half-maximal effective concentration: 417 nM
Beside the measured number, compound 4's estimate is 2.1-fold (0.32 log units) below it; low and high end bracket the measured number.
By their numbers in this assay, from the lowest: compound 2; then compound 4; then compound 3; then compound 1.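

In this assay, among these compounds, this pair gives the first direct reading of the change: methyl in place of hydrogen on a saturated chain carbon, two bonds along the chain from a carbonyl carbon, which turns the propanoyl into the propylcarbonyl on the amide, brings a 2.1-fold lower number from compound 3 to compound 4 (0.32 log units; beyond the scatter) on the core the two compounds share. The step is modest but beyond the usual scatter, so this position accepts the extra methyl and the number moves down rather than up. This rests on a single pair and is no pattern, and nothing available accounts for the direction or size of the step.

It remains open whether the same change would give a step of similar size and direction on the core of compound 2, for which the compounds shown offer no propanoyl partner. From the compounds shown here alone, it is also open how far the trend runs along the chain, for instance whether a longer chain on the carbonyl, a branching methyl on this same carbon, or a hydroxyl in place of the methyl would lower the number further or raise it again.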